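Replacing a Sulfanyl Group with Pentylselanyl on a Shared Core

The source may report more compounds than this note shows. Statements on the series, on what has been measured and on what is new or still open speak of the compounds shown alone.

Of the compounds shown here, three that share one core have been tested in a functional assay on CCRF-CEM cells (Homo sapiens) for cytotoxicity, read by MTT assay, with a stated time of 72 h; on this read-out higher numbers stand for weaker inhibition of growth and lower numbers for stronger inhibition of growth. Compound 1 `CCCCC[Se]c1nc(NCc2ccc(SC)cc2)c2ccccc2n1` gives 35000 nM. Compound 2 `CCCCC[Se]c1nc([Se]CCCCC)c2ccccc2n1` gives 65700 nM. Compound 3 `Sc1nc(NCc2ccccc2)c2ccccc2n1` gives 82400 nM, the highest of the three numbers; its gap to compound 2 lies within the scatter, while its gap to compound 1 lies beyond it, so compound 1 inhibits growth more strongly than compound 3.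

Compound 4 `CCCCC[Se]c1nc(NCc2ccccc2)c2ccccc2n1` has not yet been measured. It differs from compound 3 in one place: a group of 6 heavy atoms (5 carbon, 1 selenium; no ring) in place of one sulfur atom, on an aromatic carbon. Within the data shown here, no pair of measured compounds differs in just this way, so the size of this step cannot be read directly from the data. Still, compound 1, which carries the entering group on the shared core, gave 35000 nM, and compound 2, which also carries it, gave 65700 nM. On that basis the step from compound 3 to compound 4 is expected to be modest, toward a lower number, near the edge of the scatter, a 1.8-fold lower number from compound 3 to compound 4 (0.26 log units; within the scatter). Compound 4 is estimated at 45000 nM, with a range from 15000 nM to 130000 nM.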

Compound 4, concentration for 50% growth inhibition: 34500 nM
For compound 4 the middle estimate is 1.3-fold (0.12 log units) above the measured one; measured number inside the range.
By their numbers in this assay, from the lowest: compounds 4, 1, 2 and 3 (each within the scatter of the next, the first and the last beyond it).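

In this assay, among these compounds, pentylselanyl in place of sulfanyl on the aromatic carbon between two ring nitrogen atoms gives a first direct reading of this change, and the step lies beyond the scatter (a 2.4-fold lower number from compound 3 to compound 4 (0.38 log units; beyond the scatter)). The two other new steps stay within the scatter: hydrogen in place of methylsulfanyl (a 1.0-fold lower number from compound 1 to compound 4 (0.01 log units; within the scatter)), and a group with an aromatic ring in place of a second pentylselanyl (a 1.9-fold lower number from compound 2 to compound 4 (0.28 log units; within the scatter)). Nothing measured here accounts for any of these steps.

Going by these compounds, this one step swaps the sulfur for selenium and adds the pentyl chain together, so the share of each stays open. A pentylsulfanyl group at this position would separate the two, and an ethylselanyl group or a longer chain would show how much chain length matters.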